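Ring size on the thiocarbonyl carbon: a second pair

The compounds below may be only part of what the source reports. "The series", "measured", "known", "first", "only" and "open" are said of these compounds alone.

Measured in a functional assay on A-375 cells (Homo sapiens) for cytotoxicity, read by MTT assay, with a stated time of 72 h, tested at 30 uM; a higher number here means more inhibition of growth at the concentration tested, a lower number less inhibition of growth:
compound 1 `Cc1cccc(/C(N)=N/NC(=S)N2CCCCC2)n1` gives 80.9%
compound 2 `Cc1cccc(/C(N)=N/NC(=S)N2CCCC2)n1` gives 60.8%
compound 3 `Cc1ccnc(/C(N)=N/NC(=S)N2CCCCC2)c1` gives 80%

Compound 1 and compound 3 are built from the same atoms joined differently; the difference between the two cores is not broken down here. In this assay the two lie within the scatter of each other. For the measured compounds named here, compound 2 and compound 3 share no counted step, and their values sit beyond the scatter apart. Going by the values given here, the one counted step, (pyrrolidin-1-yl in place of piperidin-1-yl on a thiocarbonyl carbon), gives a number 20.1 percentage points lower from compound 1 to compound 2 (beyond the scatter).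

Compound 4 `Cc1ccnc(/C(N)=N/NC(=S)N2CCCC2)c1` is not yet measured. It differs from compound 3 by pyrrolidin-1-yl in place of piperidin-1-yl on a thiocarbonyl carbon, the same change made at the same place as in the first pair. Since compound 1 and compound 3 are within the scatter, with compound 3 at 80%, the starting point is comparable. The change is expected to give a number 20 percentage points lower from compound 3 to compound 4 (beyond the scatter) because the first pair gave a number 20.1 percentage points lower from compound 1 to compound 2 (beyond the scatter). Compound 4 is therefore estimated at 60%, between 45% and 75%. Among the compounds with values here, only one measured step supports this expectation.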

Compound 4, percent growth inhibition at one concentration: 87.9%
Estimate against measurement, compound 4: 27.9 percentage points below, and the stated range ends below it.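

In this assay, pyrrolidin-1-yl in place of piperidin-1-yl on a thiocarbonyl carbon does not carry over as a fixed increment from one core to the other: the same change on two cores in this assay, a number 20.1 percentage points lower (beyond the scatter) from compound 1 to compound 2 and a number 7.9 percentage points higher (within the scatter) from compound 3 to compound 4, 28 percentage points apart, beyond the scatter of two such steps. On the second core the change gives a number 7.9 percentage points higher from compound 3 to compound 4 (within the scatter), so the drop seen in the first pair does not recur there, and a step measured on one of these cores is a poor guide to the other. Two pairs at one tested concentration do not show which difference between the cores, built from the same atoms joined differently, decides the outcome, nor whether the same dependence would appear with other amine rings or at other concentrations.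

The compounds shown leave open how a larger ring such as azepan-1-yl, or a ring with a second hetero atom such as morpholin-4-yl, would behave at the same place on each core. Going by these compounds, an open-chain amine such as dimethylamino is equally open.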